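Urea for amide on the carbonyl carbon of compound 3

The compounds below may be only part of what the source reports. "The series", "measured", "known", "first", "only" and "open" are said of these compounds alone.

Three amides share one core and differ only in the aryl group on the carbonyl carbon. In an assay on cells with melanin-concentrating hormone receptor 1 (Homo sapiens) as the target, read by radioligand binding (on this read-out lower numbers stand for stronger inhibition and higher numbers for weaker inhibition), compound 1 `CC(C)c1ccc(C(=O)NCCCOc2cccc3ccc(N)nc23)cc1` gives 60 nM, compound 2 `COc1cccc(C(=O)NCCCOc2cccc3ccc(N)nc23)c1` gives 2 nM, and compound 3 `Nc1ccc2cccc(OCCCNC(=O)c3cccc(Cl)c3)c2n1` gives 0.4 nM. The steps are a 30-fold lower number from compound 1 to compound 2 (1.48 log units; beyond the scatter), a 150-fold lower number from compound 1 to compound 3 (2.18 log units; beyond the scatter) and a 5.0-fold lower number from compound 2 to compound 3 (0.70 log units; beyond the scatter), so compound 3 stands lowest of the three, clear of compound 2 and far clear of compound 1.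

Compound 4 `Nc1ccc2cccc(OCCCNC(=O)Nc3cccc(Cl)c3)c2n1` keeps the core and the chlorinated aryl ring of compound 3 and changes ((3-chlorophenyl)amino in place of 3-chlorophenyl on a carbonyl carbon). Going by the values given here, none of the measured steps bears on this change: each of them swaps one aryl group for another while the carbonyl stays directly attached to the ring. Among the compounds with values here, the only guide is therefore the value of compound 3 itself in this assay, 0.4 nM, with no anchor for the new amino link. A small loss is expected in this assay, a 3.0-fold higher number from compound 3 to compound 4 (0.48 log units; beyond the scatter), but within a wide band. Compound 4 is estimated at 1.2 nM, between 0.2 nM and 8 nM.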

Compound 4, half-maximal inhibitory concentration: 0.9 nM
Compound 4: middle estimate off by 1.3-fold (0.12 log units), on the high side, within the range that was stated.
By their numbers in this assay, from the lowest: compound 3; then compound 4; then compound 2; then compound 1.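

In this assay, the carbonyl carbon of this series accepts a urea as well as an amide: the change to (3-chlorophenyl)amino, which brings in one nitrogen and one hydrogen-bond donor, carries only a modest penalty (a 2.3-fold higher number from compound 3 to compound 4 (0.35 log units; beyond the scatter)). The urea compound 4 still reads lower than both other amides (a 2.2-fold lower number from compound 2 to compound 4 (0.35 log units; beyond the scatter); a 67-fold lower number from compound 1 to compound 4 (1.82 log units; beyond the scatter)), so direct attachment of the aryl ring to the carbonyl carbon is not needed for a low number in this set. No evidence is available on why the urea reads slightly higher than the amide.

Open, from the compounds shown here alone, is whether the same small penalty applies with the 3-methoxyphenyl or 4-isopropylphenyl groups of compounds 2 and 1. Also open, going by these compounds, is how a methylene link or a longer chain on the carbonyl carbon would read.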